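Swapping the oxadiazole for imidazole on the shared core

The source may hold more compounds than are shown below. What is called first, only, known or untested is meant among the compounds shown, and "the series" means these compounds.

Compound 1 `OCc1nnc(-c2ccc(N3CCC(Oc4ccccc4C(F)(F)F)CC3)nn2)s1`: 3.2 nM
Compound 2 `CCc1ccccc1OC1CCN(c2ccc(-n3ccnc3)nn2)CC1`: 4 nM
Compound 3 `CC(C)Cc1nnc(-c2ccc(N3CCC(Oc4ccccc4C(F)(F)F)CC3)nn2)o1`: 15 nM

In an assay on microsomes from liver for inhibition of acyl-CoA desaturase 1 (Rattus norvegicus) (a lower number here means a stronger inhibitor, a higher number a weaker inhibitor), compound 3 gives the highest of the three numbers, so it is the weakest inhibitor measured here. Among the compounds with values here, the one recorded step leading to it, a 4.7-fold higher number from compound 1 to compound 3 (0.67 log units; beyond the scatter), changes a different group and so does not speak to the move now considered. Compound 4 `FC(F)(F)c1ccccc1OC1CCN(c2ccc(-n3ccnc3)nn2)CC1` differs from compound 3 as follows: 1H-imidazol-1-yl in place of 5-isobutyl-1,3,4-oxadiazol-2-yl on an aromatic carbon. Within the data shown here, no measured pair isolates this change. Compound 2 already carries the imidazolyl group, and in this assay compound 2 gives 4 nM, whereas compound 3 gives 15 nM. A step of about a 3.8-fold lower number from compound 3 to compound 4 (0.57 log units; beyond the scatter) toward a lower number is therefore expected. Compound 4 is estimated at 4 nM, within 1.5 nM to 12 nM.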

Compound 4, half-maximal inhibitory concentration: 4 nM
For compound 4 middle estimate and measured number coincide at the digits printed; low and high end bracket the measured number.
By their numbers in this assay, from the lowest: compounds 1, 2 and 4 (each within the scatter of the next); then compound 3.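

Replacing 5-isobutyl-1,3,4-oxadiazol-2-yl with 1H-imidazol-1-yl gives a 3.8-fold lower number from compound 3 to compound 4 (0.57 log units; beyond the scatter) in this assay, so this position does not need the isobutyl chain for a low number. With the imidazolyl group in place, trifluoromethyl in place of ethyl gives no change at the digits printed from compound 2 to compound 4 (within the scatter). 1H-imidazol-1-yl in place of 5-(hydroxymethyl)-1,3,4-thiadiazol-2-yl gives a 1.3-fold higher number from compound 1 to compound 4 (0.10 log units; within the scatter), so these two groups cannot be told apart here.

Nothing shown gives a reason for these steps. Still open, on these data alone, is how an amine or a carboxylic acid at this position would read in this assay.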